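Lengthening the Alkyl Chain of an Indole Amide

A few compounds are considered here, and "the series" means these few. Any claim that something is new, unique, unknown or untested is made for them only; others in the source may bear on it.

Compound 1 `CCCCCCCCCCCCNC(=O)[C@@H](NC(=O)c1cc2ccccc2[nH]1)[C@@H](C)O` stands lowest of the two numbers seen in a functional assay on SW-620 cells (Homo sapiens) for cytotoxicity, read by MTT assay, with a stated time of 48 h (on this read-out higher numbers stand for weaker inhibition and lower numbers for stronger inhibition), where compound 1 gives 18800 nM. Compound 2 `CCCCCCCCCCCCNC(=O)[C@@H](NC(=O)/C=C/c1ccccc1)[C@@H](C)O` gives 200000 nM in this assay, and the step of an 11-fold higher number from compound 1 to compound 2 (1.03 log units; beyond the scatter) changed only the group on the carbonyl carbon. Compound 3 `CCCCCCCCCCCCCCCCCCNC(=O)[C@@H](NC(=O)c1cc2ccccc2[nH]1)[C@@H](C)O` differs from compound 1 by hexyl in place of hydrogen on a saturated chain carbon, ten or more bonds along the chain from an amide-type nitrogen. Within the data shown here, no measured step touches this part of the molecule, so the only guide is the number for compound 1 itself. Compound 3 is therefore expected to stay near the same level, a step of no change at the digits printed from compound 1 to compound 3 (within the scatter) with no direction assumed. The estimate for compound 3 is 18800 nM, within 6000 nM to 60000 nM.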

Compound 3, half-maximal inhibitory concentration: 23600 nM
Estimate against measurement, compound 3: 1.3-fold (0.10 log units) below; measured number inside the range.
By their numbers in this assay, from the lowest: compounds 1 and 3 (each within the scatter of the next); then compound 2.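

Hexyl in place of hydrogen on a saturated chain carbon gives in this assay a 1.3-fold higher number from compound 1 to compound 3 (0.10 log units; within the scatter). So at this position, the longer chain leaves the number within the scatter, whereas the only earlier step, at the carbonyl carbon, was large: an 11-fold higher number from compound 1 to compound 2 (1.03 log units; beyond the scatter). Nothing measured here offers a reason for this result. The compounds shown leave open how a much shorter chain would read, and whether an amine or a carboxylic acid on the chain would hold the same level.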